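Notes on benzyl-ring substituents: compound 3 to compound 4

The source may report more compounds than this note shows. Statements on the series, on what has been measured and on what is new or still open speak of the compounds shown alone.

All numbers below come from a functional assay on A2780 cells (Homo sapiens) for inhibition, read by MTT assay, with a stated time of 72 h; a higher number here means a weaker inhibitor of growth, a lower number a stronger inhibitor of growth.

Compound 1 `O=S(=O)(NCCCNCc1ccccc1Cl)c1cc(C(F)(F)F)cc(C(F)(F)F)c1`: 9300 nM
Compound 2 `O=S(=O)(NCCCNCc1ccc(Cl)c(Cl)c1)c1cc(C(F)(F)F)cc(C(F)(F)F)c1`: 1500 nM
Compound 3 `O=S(=O)(NCCCNCc1ccc(C(F)(F)F)cc1)c1cc(C(F)(F)F)cc(C(F)(F)F)c1`: 2800 nM

Compound 3 stands second highest of the three numbers. Its nearest neighbour is compound 2, with a 1.9-fold higher number from compound 2 to compound 3 (0.27 log units; within the scatter); its furthest is compound 1, with a 3.3-fold lower number from compound 1 to compound 3 (0.52 log units; beyond the scatter). Compound 4 `O=S(=O)(NCCCNCc1ccc(Br)cc1)c1cc(C(F)(F)F)cc(C(F)(F)F)c1` is the next member and differs from compound 3 by bromo in place of trifluoromethyl on an aromatic carbon. Within the data shown here, no measured step changes only that group; the steps that bear on it rearrange the whole substitution pattern of the benzyl ring: a 6.2-fold lower number from compound 1 to compound 2 (0.79 log units; beyond the scatter) and a 3.3-fold lower number from compound 1 to compound 3 (0.52 log units; beyond the scatter), both modest. Compound 2 and compound 3, the two carrying a halogen or trifluoromethyl away from the attachment point, lie within the scatter of each other, so the identity of that distal group has so far mattered little. A step within the scatter is therefore expected, a 1.1-fold lower number from compound 3 to compound 4 (0.05 log units; within the scatter). For compound 4 the estimate in this assay is 2500 nM, with a range from 1000 nM to 7000 nM.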

Compound 4, concentration for 50% growth inhibition: 2600 nM
Estimate against measurement, compound 4: 1.0-fold (0.02 log units) below; measured number inside the range.
By their numbers in this assay, from the lowest: compounds 2, 4 and 3 (each within the scatter of the next); then compound 1.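

In this assay, among these compounds, this is the first exchange made at this place alone, on an aromatic carbon para to a large group. It gives a 1.1-fold lower number from compound 3 to compound 4 (0.03 log units; within the scatter), so bromo, with 1 heavy atom, and trifluoromethyl, with 4 heavy atoms, are not told apart here. The 4-bromophenyl group also gives a 1.7-fold higher number from compound 2 to compound 4 (0.24 log units; within the scatter) against 3,4-dichlorophenyl and a 3.6-fold lower number from compound 1 to compound 4 (0.55 log units; beyond the scatter) against 2-chlorophenyl, which leaves compound 1 apart from the other three, and nothing available explains the match between bromo and trifluoromethyl.

From the compounds shown here alone, whether this flat response holds for an amine, a carboxylic acid or a nitrile on the same aromatic carbon remains open. So does the effect of a longer chain in the shared core, with the benzyl ring unchanged.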